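The Same Change Made on Two Different Cores

The source may hold more compounds than are shown below. What is called first, only, known or untested is meant among the compounds shown, and "the series" means these compounds.

Compound 1 `CC(C)(C)[Si](C)(C)O[C@H]1CC[C@H](n2cc(-c3ccc4cnn(Cc5ccc6ncccc6c5)c4c3)cn2)CC1` gives 11000 nM in a functional assay on MKN-45 cells (Homo sapiens) for cytotoxicity, read by Western blot, with a stated time of 1 h; on this read-out lower numbers stand for stronger inhibition and higher numbers for weaker inhibition. Compound 2 `O[C@H]1CC[C@H](n2cc(-c3ccc4cnn(Cc5ccc6ncccc6c5)c4c3)cn2)CC1` gives 5450 nM. Compound 3 `CC(C)(C)[Si](C)(C)O[C@H]1CC[C@H](n2cc(-c3ccc4cn(Cc5ccc6ncccc6c5)nc4c3)cn2)CC1` gives 1300000 nM.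

Compound 2 differs from compound 1 by a hydrogen atom in place of a group of 7 heavy atoms (6 carbon, 1 silicon; no ring), on an oxygen on a saturated carbon and this gave a 2.0-fold lower number from compound 1 to compound 2 (0.30 log units; within the scatter). Compound 3 is built from the same atoms as compound 1, joined differently; the difference between the two cores is not broken down here, but compound 3 stands far higher than both compound 1 and compound 2. Compound 4 `O[C@H]1CC[C@H](n2cc(-c3ccc4cn(Cc5ccc6ncccc6c5)nc4c3)cn2)CC1` differs from compound 3 by a hydrogen atom in place of a group of 7 heavy atoms (6 carbon, 1 silicon; no ring), on an oxygen on a saturated carbon, the same change at the same kind of place. The step to compound 4 is expected to be small because a 2.0-fold lower number from compound 1 to compound 2 (0.30 log units; within the scatter) lay within the scatter, so an expected step of a 2.0-fold lower number from compound 3 to compound 4 (0.30 log units; within the scatter) follows. The estimate for compound 4 in this assay is 650000 nM, between 250000 nM and 1600000 nM.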

Compound 4, half-maximal inhibitory concentration: 13400 nM
Compound 4: the middle estimate sits 49-fold (1.69 log units) above what was measured; the measured number lies below the stated range.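

Replacing the group of 7 heavy atoms (6 carbon, 1 silicon) with a hydrogen atom gave a 97-fold lower number from compound 3 to compound 4 (1.99 log units; beyond the scatter) in this assay. This pair of cores alone does not show why the two results part, or how the change would behave on any third core. What can be said is that, in this series, the size of the step on one core did not predict its size on the other: the same change on two cores in this assay, a 2.0-fold lower number (0.30 log units; within the scatter) from compound 1 to compound 2 and a 97-fold lower number (1.99 log units; beyond the scatter) from compound 3 to compound 4, 48-fold (1.68 log units) apart, beyond the scatter of two such steps

The compounds shown leave open what other groups on that oxygen, such as a methyl or a longer chain, would do on either core. They also leave open whether an amine in place of that oxygen would show the same gap between the two cores.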